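Swapping chloro for fluoro on two arms of a shared core

This account rests on a few compounds, and the source may have more. Where it says the series, first, only, none or still open, it means among the compounds named here.

Measured compounds:
compound 1, `N#Cc1c(Nc2ccccc2Cl)nc(SCc2cn(Cc3ccccc3Cl)nn2)nc1-c1ccccc1`, 4640 nM
compound 2, `N#Cc1c(Nc2ccccc2F)nc(SCc2cn(Cc3ccccc3Cl)nn2)nc1-c1ccccc1`, 7580 nM
compound 3, `Cc1ccc(Nc2nc(SCc3cn(Cc4ccc(Cl)cc4)nn3)nc(-c3ccccc3)c2C#N)cc1`, 19600 nM

All three were tested in a functional assay on MGC-803 cells (Homo sapiens) for inhibition, read by MTT assay, with a stated time of 72 h; a lower number here means a stronger inhibitor, a higher number a weaker inhibitor. Among the compounds with values here, compound 1 and compound 2 share a core, and the only change between them is fluoro in place of chloro on an aromatic carbon; that change made a step of a 1.6-fold higher number from compound 1 to compound 2 (0.21 log units; within the scatter). Compound 3 carries a different core; how it differs from compound 1 is not broken down here, and in this assay compound 3 gives the highest of the three numbers.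

Compound 4, `Cc1ccc(Nc2nc(SCc3cn(Cc4ccc(F)cc4)nn3)nc(-c3ccccc3)c2C#N)cc1`, is not yet measured. It differs from compound 3 by fluoro in place of chloro on an aromatic carbon. Within the data shown here, this is the same kind of change as the one from compound 1 to compound 2, but not the same: there the fluoro sits ortho to a large group, here it sits para to a large group. Since the earlier step stayed within the scatter, a comparably small step is expected from compound 3 to compound 4, namely a 1.3-fold higher number from compound 3 to compound 4 (0.12 log units; within the scatter), resting on the step of a 1.6-fold higher number from compound 1 to compound 2 (0.21 log units; within the scatter). For compound 4 the estimated value is 26000 nM, expected to lie between 10000 nM and 65000 nM.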

Compound 4, half-maximal inhibitory concentration: > 64000 nM
Compound 4: a limit, no number; the forecaster's own chance of this, stated with the estimate: 15%; at least 2.4-fold (0.39 log units) between middle value and limit.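

In this assay compound 4 gives > 64000 nM, which is a limit of the assay and not a number. Going from 4-chlorobenzyl to 4-fluorobenzyl gives an at least 3.2-fold higher number from compound 3 to compound 4 (0.51 log units; beyond the scatter), so this change goes beyond the scatter here, while on the core of compound 1 it stayed within the scatter. This does not show that the change truly behaves differently on the two cores, because the real size of the newer step is unknown: the same change on two cores in this assay, a 1.6-fold higher number (0.21 log units; within the scatter) from compound 1 to compound 2 and an at least 3.2-fold higher number (0.51 log units; beyond the scatter) from compound 3 to compound 4; the limit leaves it open whether they differ

Among the compounds shown, the change sits in a different place on each core, so the effect of its place cannot be separated from the effect of the core. On these data alone, it also remains open how a methyl group, a methoxy group or a trifluoromethyl group would compare with chloro and fluoro on the benzyl group of this series.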